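The source may hold more compounds than are shown below. What is called first, only, known or untested is meant among the compounds shown, and "the series" means these compounds.

Measured so far in a functional assay on A549 cells (Homo sapiens) for inhibition, read by MTT assay, with a stated time of 72 h; on this read-out higher numbers stand for weaker inhibition and lower numbers for stronger inhibition: compound 1 `CN(C(=O)NC(=O)c1ccc(Cl)cc1Cl)c1nc(C(F)(F)F)c(C(=O)N/N=C/c2cccc(C(F)(F)F)c2)s1` gives 10.6 ug/mL; compound 2 `CN(C(=O)NC(=O)c1ccccc1F)c1nc(C(F)(F)F)c(C(=O)N/N=C/c2cc(C(F)(F)F)cc(C(F)(F)F)c2)s1` gives 5.43 ug/mL; compound 3 `CN(C(=O)NC(=O)c1ccc(F)c(F)c1)c1nc(C(F)(F)F)c(C(=O)N/N=C/c2cc(C(F)(F)F)cc(C(F)(F)F)c2)s1` gives 5.47 ug/mL.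

Compound 3 stands second highest of the three numbers in this assay, yet its value is within the scatter of those of compound 2 and compound 1. Compound 4 `CN(C(=O)NC(=O)c1ccc(Cl)cc1Cl)c1nc(C(F)(F)F)c(C(=O)N/N=C/c2cc(C(F)(F)F)cc(C(F)(F)F)c2)s1` differs from compound 3 by 2,4-dichlorophenyl in place of 3,4-difluorophenyl on a carbonyl carbon. Among the compounds with values here, one measured step bears on this change, the exchange of the benzoyl aryl from compound 2 to compound 3, which gave a 1.0-fold higher number from compound 2 to compound 3 (0.00 log units; within the scatter). Compound 1, which already carries the 2,4-dichlorophenyl on the carbonyl carbon, shows a value in this assay that lies within the scatter of compound 3. The step is therefore expected to be a 1.3-fold higher number from compound 3 to compound 4 (0.11 log units; within the scatter), nothing beyond the scatter. Compound 4 is estimated at 7 ug/mL in this assay, with a range from 3.5 ug/mL to 14 ug/mL.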

Compound 4, half-maximal inhibitory concentration: > 100 ug/mL
Compound 4 was reported as a limit; the forecaster's own chance of this, stated with the estimate: 2%; middle value at least 14-fold (1.15 log units) from the limit.
By their numbers in this assay, from the lowest: compounds 2, 3 and 1 (each within the scatter of the next). At a limit, above all of these: compound 4.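

In this assay compound 4 gives > 100 ug/mL, a limit of the assay and not a number. The aryl group on this carbonyl carbon can matter after all: 2,4-dichlorophenyl gives an at least 18-fold higher number from compound 3 to compound 4 (1.26 log units; beyond the scatter) and an at least 18-fold higher number from compound 2 to compound 4 (1.26 log units; beyond the scatter), whereas the earlier exchange there stayed within the scatter. The 2,4-dichlorophenyl alone does not settle the outcome: trifluoromethyl in place of hydrogen on an aromatic carbon gives an at least 9.4-fold higher number from compound 1 to compound 4 (0.97 log units; beyond the scatter).

As far as these compounds go, it remains open whether a 4-chlorophenyl or a 4-methoxyphenyl on this carbonyl carbon, with the rest of compound 4 unchanged, would read like compound 3 or like compound 4.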